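This account rests on a few compounds, and the source may have more. Where it says the series, first, only, none or still open, it means among the compounds named here.

Measured in a functional assay on MCF7 cells (Homo sapiens) for antiproliferative activity, read by MTT assay, with a stated time of 72 h; on this read-out lower numbers stand for stronger inhibition and higher numbers for weaker inhibition:
- Compound 1 `COc1cc2c(Nc3ccc(C#N)cc3)ncnc2cc1OCCCN(C)C`: 45000 nM
- Compound 2 `COc1cc2c(Nc3ccc(C#N)cc3)ncnc2cc1OCCCN1CCC(C)CC1`: 43100 nM
- Compound 3 `COc1cc2c(Nc3ccc(C#N)cc3)ncnc2cc1OCCCN1CCC(c2ccccc2)CC1`: 9800 nM

Compound 2, at 43100 nM, stands level with compound 1 within the scatter, while compound 3 lies lower. Compound 4 `COc1cc2c(Nc3ccc(C#N)cc3)ncnc2cc1OCCCN1CCC(N(C)C)CC1` has dimethylamino in place of methyl on a saturated ring carbon, three ring bonds from the ring nitrogen: dimethylamino in place of methyl on a saturated ring carbon.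

Among the measured compounds shown here, two measured steps bear on this change. For the measured compounds named here, the only change measured at this ring carbon gave a 4.4-fold lower number from compound 2 to compound 3 (0.64 log units; beyond the scatter), with phenyl in place of methyl. Exchanging the whole amine on the chain gave a 1.0-fold lower number from compound 1 to compound 2 (0.02 log units; within the scatter). Dimethylamino, like the methyl of compound 2, has no ring, whereas the phenyl of compound 3 has one. The flat step is therefore taken as the closer guide, and no step beyond the scatter is expected in this assay, though a slight fall in the number is possible. The estimated change is a 1.4-fold lower number from compound 2 to compound 4 (0.16 log units; within the scatter). For compound 4 the estimated value is 30000 nM, with an expected range of 11000 nM to 70000 nM.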

Compound 4, half-maximal inhibitory concentration: 31000 nM
Compound 4: the middle estimate sits 1.0-fold (0.01 log units) below what was measured, and the stated range covers the measured number.
By their numbers in this assay, from the lowest: compound 3; then compounds 4, 2 and 1 (each within the scatter of the next).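

In this assay, putting dimethylamino at this ring carbon, three ring bonds from the ring nitrogen, gave a 1.4-fold lower number from compound 2 to compound 4 (0.14 log units; within the scatter), and the whole 4-(dimethylamino)piperidin-1-yl group in place of the plain dimethylamino gave a 1.5-fold lower number from compound 1 to compound 4 (0.16 log units; within the scatter). Dimethylamino in place of phenyl gave a 3.2-fold higher number from compound 3 to compound 4 (0.50 log units; beyond the scatter), so among the three groups shown at this ring carbon only phenyl stands apart, while methyl and dimethylamino, neither of which has a ring, stay level. Nothing measured here explains this difference.

From the compounds shown here alone, whether a cyclohexyl, pyridyl or benzyl group at this ring carbon would match phenyl remains open. So does whether a hydroxyl or carboxylic acid there, or a longer chain carrying the same amine, would shift the number in this assay.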